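Swapping Pyrrolidin-1-yl for Dimethylamino on a Carbonyl Carbon

This account rests on a few compounds, and the source may have more. Where it says the series, first, only, none or still open, it means among the compounds named here.

The compounds here share one core, seen without a side group in compound 1 (`CC(C)n1cc(-c2ccnc3[nH]c(C4CCNCC4)cc23)ccc1=O`), which in a physicochemical assay for lipophilicity, using the shake flask method, measured as octanol-water partition, at pH 7.4 (on this read-out higher numbers stand for higher lipophilicity and lower numbers for lower lipophilicity), gives -0.2. Compound 2 (`CNC(=O)CN1CCC(c2cc3c(-c4ccc(=O)n(C(C)C)c4)ccnc3[nH]2)CC1`) carries (methylcarbamoyl)methyl in place of hydrogen on an amine nitrogen in a ring and gives 2.2. Compound 3 (`CC(C)n1cc(-c2ccnc3[nH]c(C4CCN(CC(=O)N5CCCC5)CC4)cc23)ccc1=O`) carries ((pyrrolidin-1-yl)carbonyl)methyl there and gives 2.1, which puts it level with compound 2 and far from compound 1.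

Compound 4 (`CC(C)n1cc(-c2ccnc3[nH]c(C4CCN(CC(=O)N(C)C)CC4)cc23)ccc1=O`) has not been measured. Its difference from compound 3 is dimethylamino in place of pyrrolidin-1-yl on a carbonyl carbon. The large steps, a number 2.40 log units higher from compound 1 to compound 2 (beyond the scatter) and a number 2.30 log units higher from compound 1 to compound 3 (beyond the scatter), come from adding the whole side group, so they say little about this swap. The closest guide is the exchange on the same carbonyl carbon, a number 0.10 log units lower from compound 2 to compound 3 (within the scatter), though it is a single comparison. In this assay only a small change is therefore expected, a number 0.20 log units lower from compound 3 to compound 4 (within the scatter), which would not go beyond the scatter. The estimate for compound 4 is 1.9, with an expected range from 1.5 to 2.3.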

Compound 4, distribution coefficient: 1.9
Beside the measured number, compound 4's estimate shows no gap at the digits printed, within the range that was stated.
By their numbers in this assay, from the lowest: compound 1; then compounds 4, 3 and 2 (each within the scatter of the next).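

Trading pyrrolidin-1-yl for dimethylamino on this carbonyl carbon, which removes the ring, hardly shifts the number in this assay (a number 0.20 log units lower from compound 3 to compound 4 (within the scatter)). Adding a methyl on the amide-type nitrogen gives a step that also stays inside the scatter (a number 0.30 log units lower from compound 2 to compound 4 (within the scatter)), so the methylamino, pyrrolidin-1-yl and dimethylamino ends cannot be told apart in this read-out. A third side group now shows a large step from the unsubstituted ring nitrogen (a number 2.10 log units higher from compound 1 to compound 4 (beyond the scatter)), and this holds for all three side groups shown.

Still open, as far as these compounds go, is whether a different end on this carbonyl carbon, such as a piperazine ring, a longer chain on the amide nitrogen, or a carboxylic acid in place of the amide, would go beyond the scatter. Nothing available here explains these numbers.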